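Bromo-oxindole series: methoxyphenyl for hydroxyphenyl on the saturated ring

The source may report more compounds than this note shows. Statements on the series, on what has been measured and on what is new or still open speak of the compounds shown alone.

Measured compounds:
compound 1 `O=C1N=C(N2N=C(c3ccccc3)CC2c2ccccc2O)S/C1=C1/C(=O)Nc2ccc(Br)cc21`: 940 nM
compound 2 `COc1ccc(C2CC(c3ccccc3)=NN2C2=NC(=O)/C(=C3\C(=O)Nc4ccccc43)S2)cc1`: 19000 nM

In a functional assay on cells (Cancer cell lines, Homo sapiens) for cytotoxicity, read by sulforhodamine B assay, with a stated time of 48 h (a higher number here means a weaker inhibitor of growth, a lower number a stronger inhibitor of growth), compound 1 gives 940 nM, the lower of the two numbers; compound 2 gives 19000 nM, a gap beyond the scatter. Compound 3 `COc1ccc(C2CC(c3ccccc3)=NN2C2=NC(=O)/C(=C3\C(=O)Nc4ccc(Br)cc43)S2)cc1` is unmeasured. Against compound 1 the difference is 4-methoxyphenyl in place of 2-hydroxyphenyl on a saturated ring carbon. Compound 3 shares the 4-methoxyphenyl of compound 2, whose value in this assay is much higher, so the step is expected to go upward, beyond the scatter, as a 4.3-fold higher number from compound 1 to compound 3 (0.63 log units; beyond the scatter). Compound 3 is thus estimated at 4000 nM, with a range from 1000 nM to 16000 nM.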

Compound 3, concentration for total growth inhibition: 3630 nM
For compound 3 the middle estimate is 1.1-fold (0.04 log units) above the measured one; the measured number falls inside the stated range.
By their numbers in this assay, from the lowest: compound 1; then compound 3; then compound 2.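

In this assay the change on the saturated ring carbon is now seen on its own with the bromo kept: 4-methoxyphenyl in place of 2-hydroxyphenyl weakens growth inhibition (a 3.9-fold higher number from compound 1 to compound 3 (0.59 log units; beyond the scatter)). With the 4-methoxyphenyl kept, bromo in place of hydrogen on an aromatic carbon strengthens it (a 5.2-fold lower number from compound 2 to compound 3 (0.72 log units; beyond the scatter)). Nothing available accounts for either step.

The compounds shown cannot separate the change of group from the change of its place on the phenyl, which 2-methoxyphenyl and 4-hydroxyphenyl would do. From the compounds shown here alone, how a carboxylic acid on that phenyl would read also stays open.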